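A few compounds are considered here, and "the series" means these few. Any claim that something is new, unique, unknown or untested is made for them only; others in the source may bear on it.

Compound 1 (`COc1cc(OC)c(OC)cc1/C=C/C(=O)c1ccccc1`): 2.23 ug/mL
Compound 2 (`COc1cc(OC)c(OC)cc1/C=C/C(=O)c1cccc(C(F)(F)F)c1`): 2.3 ug/mL

In a functional assay on cells (Erythrocyte, Rattus norvegicus) for inhibition, read by hemolysis, with a stated time of 1 h (on this read-out higher numbers stand for weaker inhibition and lower numbers for stronger inhibition), compound 2 gives 2.3 ug/mL and stands level with compound 1 within the scatter, so the two numbers cannot be told apart. Compound 3 (`COc1cc(OC)c(OC)cc1/C=C/C(=O)c1cccc([N+](=O)[O-])c1`) has not yet been measured. It carries nitro in place of trifluoromethyl on an aromatic carbon. Among the compounds with values here, only one measured step bears on this swap, and only indirectly: trifluoromethyl in place of hydrogen gave a 1.0-fold higher number from compound 1 to compound 2 (0.01 log units; within the scatter) and so stayed within the scatter. Within the data shown here, no measured compound carries nitro, so the data offer no direct guide to that group. On this thin evidence, no shift beyond the scatter is expected, and the estimated step is no change at the digits printed from compound 2 to compound 3 (within the scatter) with no firm direction. Compound 3 is estimated at 2.3 ug/mL with 1 ug/mL to 5 ug/mL as the expected range.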

Compound 3, half-maximal inhibitory concentration: 2.21 ug/mL
Beside the measured number, compound 3's estimate is 1.0-fold (0.02 log units) above it, and the stated range covers the measured number.
By their numbers in this assay, from the lowest: compounds 3, 1 and 2 (each within the scatter of the next).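

In this assay, nitro in place of trifluoromethyl gives a 1.0-fold lower number from compound 2 to compound 3 (0.02 log units; within the scatter), and nitro in place of hydrogen gives a 1.0-fold lower number from compound 1 to compound 3 (0.00 log units; within the scatter) on the same aromatic carbon. Hydrogen, trifluoromethyl and nitro differ in their atoms, and nitro alone among the two larger groups carries hydrogen-bond acceptors, yet all three compounds stand level within the scatter, so this position, meta to a large group, has now accepted two quite different groups rather than one. No measurement is available that would explain this flat result.

On these data alone, whether an amine or a carboxylic acid at this same place would move the number beyond the scatter remains open. Also open, as far as these compounds go, is whether any change elsewhere in the shared core would matter more than these swaps.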